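Swapping bromo for nitro on a bis-indolyl scaffold

The source may hold more compounds than are shown below. What is called first, only, known or untested is meant among the compounds shown, and "the series" means these compounds.

Of the compounds shown here, three from this series have been tested in a functional assay on MCF7 cells (Homo sapiens) for inhibition, read by MTT assay, with a stated time of 48 h (on this read-out lower numbers stand for stronger inhibition and higher numbers for weaker inhibition), and a fourth awaits its result. Compound 1 `O=[N+]([O-])c1ccc2[nH]cc(C(c3ccc(Br)cc3)c3c[nH]c4ccc([N+](=O)[O-])cc34)c2c1` carries a bromo group on its phenyl ring; in this assay compound 1 reaches only the limit of > 100000 nM, which is a limit rather than a number. Compound 2 `O=[N+]([O-])c1ccc(C(c2c[nH]c3ccc([N+](=O)[O-])cc23)c2c[nH]c3ccc([N+](=O)[O-])cc23)cc1` differs from compound 1 in one place: nitro in place of bromo on an aromatic carbon. In this assay compound 2 gives 22500 nM. That change gives an at least 4.4-fold lower number from compound 1 to compound 2 (0.64 log units; beyond the scatter), though the starting point is the limit of > 100000 nM in this assay, at which 1 of the 3 values shown sits, so the true size of the step is not pinned down.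

Compound 3 `OC[C@H]1O[C@@H](n2cc(C(c3ccc(Br)cc3)c3cn([C@@H]4O[C@H](CO)[C@@H](O)[C@H](O)[C@H]4O)c4ccc(Br)cc34)c3cc(Br)ccc32)[C@H](O)[C@@H](O)[C@@H]1O` has a different core from compound 1, and the difference between the two cores is not broken down here. In this assay, among the compounds with values here, compound 3 gives 51100 nM, the highest of the two numbers measured so far.

Compound 4 `O=[N+]([O-])c1ccc(C(c2cn([C@@H]3O[C@H](CO)[C@@H](O)[C@H](O)[C@H]3O)c3ccc(Br)cc23)c2cn([C@@H]3O[C@H](CO)[C@@H](O)[C@H](O)[C@H]3O)c3ccc(Br)cc23)cc1` is related to compound 3 by the same change: nitro in place of bromo on an aromatic carbon. Within the data shown here, since the place line reads the same in both pairs, this is the same change as the one from compound 1 to compound 2, now made on the other core. On that basis the step is expected to be a 3.4-fold lower number from compound 3 to compound 4 (0.53 log units; beyond the scatter), resting on the direction seen in an at least 4.4-fold lower number from compound 1 to compound 2 (0.64 log units; beyond the scatter), though the core differs and the earlier step starts from a limit. Compound 4 is therefore estimated to give 15000 nM in this assay, with a likely range from 5000 nM to 50000 nM.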

Compound 4, half-maximal inhibitory concentration: 66700 nM
Compound 4: the middle estimate sits 4.4-fold (0.65 log units) below what was measured, and the stated range ends below it.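

Carrying the change from bromo to nitro over to the second core did not repeat the result seen on the first, since this assay gives a 1.3-fold higher number from compound 3 to compound 4 (0.12 log units; within the scatter), and the two steps differ: the same change on two cores in this assay, an at least 4.4-fold lower number (0.64 log units; beyond the scatter) from compound 1 to compound 2 and a 1.3-fold higher number (0.12 log units; within the scatter) from compound 3 to compound 4, at least 5.8-fold (0.76 log units) apart, beyond the scatter of two such steps

Within the data shown here, with only one pair on each core, this shows that the outcome of this change can depend on the core, but it does not show which part of the core matters or how widely the finding holds. Compound 1, where the first step begins, stands at a limit and not a number, so the true size of the gap between the two steps stays unknown: the limit of > 100000 nM in this assay, at which 1 of the 4 values shown sits.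

The compounds shown carry only bromo or nitro at this place on the phenyl ring, so it stays open how an amine, a carboxylic acid or a methoxy group would behave there on either core. On these data alone, every value shown also comes from this assay, so whether the two cores would part in the same way on other cells remains open too.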